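A Benzothiophene in Place of Phenyl on a Macrocycle

The compounds below may be only part of what the source reports. "The series", "measured", "known", "first", "only" and "open" are said of these compounds alone.

Compound 1, `CCC[C@@H]1NC(=O)[C@@H](C(C)C)NC(=O)[C@@H](Cc2ccccc2)NCCOc2ccccc2/C=C/CNC1=O`, gives 78 nM in an assay on isolated protein for displacement of a labelled ligand from Motilin receptor (Homo sapiens); a higher number here means a weaker inhibitor, a lower number a stronger inhibitor. Compound 3, `CCC[C@@H]1NC(=O)[C@@H](C(C)C)NC(=O)[C@@H](Cc2ccccc2)NCCOc2ccccc2CCCNC1=O`, gives 57 nM in this assay. Compound 2, `CCC[C@@H]1NC(=O)[C@@H](C(C)C)NC(=O)[C@@H](Cc2ccc(O)cc2)NCCCc2ccccc2/C=C/CNC1=O`, gives > 10000 nM in this assay, a limit of the assay and not a number. Its value is the limit of > 10000 nM in this assay, at which 1 of the 3 values shown sits.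

Compound 3 and compound 1 thus stand close together: the gap between their two numbers lies within the usual scatter of this assay, so they cannot be told apart on these data. Compound 2 differs from both in more than one place, so its limit says nothing about any single change.

Compound 4, `CCC[C@@H]1NC(=O)[C@@H](C(C)C)NC(=O)[C@@H](Cc2csc3ccccc23)NCCOc2ccccc2CCCNC1=O`, has not yet been measured. It differs from compound 3 in one place: 1-benzothiophen-3-yl in place of phenyl on a saturated chain carbon bound to a saturated ring carbon. For the measured compounds named here, no measured pair shows what exchanging this aromatic group alone does, so the direction of the step is open. A moderate shift toward a weaker inhibitor seems the more likely outcome, but a result within the scatter of compound 3 would not surprise. Compound 4 is expected to give 110 nM in this assay, most likely between 30 nM and 450 nM. This estimate means a step of a 1.9-fold higher number from compound 3 to compound 4 (0.29 log units; within the scatter).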

Compound 4, inhibition constant: 11 nM
For compound 4 the middle estimate is 10-fold (1.00 log units) above the measured one; measured number below the stated range.
By their numbers in this assay, from the lowest: compound 4; then compounds 3 and 1 (each within the scatter of the next). At a limit, above all of these: compound 2.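

Exchanging phenyl for 1-benzothiophen-3-yl on a saturated chain carbon bound to a saturated ring carbon gives a 5.2-fold lower number from compound 3 to compound 4 (0.71 log units; beyond the scatter) in this assay, the only single-place step among the compounds shown, and the first sign that a change at this position can move the number beyond the scatter. The position therefore accepts more than a single aromatic ring: benzyl to (1-benzothiophen-3-yl)methyl adds a five-membered aromatic ring holding sulfur to the six-membered one, and the result is a stronger inhibitor, not a loss of binding. Nothing measured here explains this gain, and it cannot be assigned to the sulfur or to the added ring.

A naphthyl group, which has two fused six-membered rings of carbon only, or an indol-3-yl group, which has nitrogen where the benzothiophene has sulfur, would show at this same place whether the sulfur itself counts or whether a second fused ring is enough. Also open, on these data alone, is whether the same exchange gives a similar step on the core of compound 1, which carries the chain with the double bond.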